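Isopropyl in Place of 3-Methoxyphenyl on Two Related Cores

A few compounds are considered here, and "the series" means these few. Any claim that something is new, unique, unknown or untested is made for them only; others in the source may bear on it.

Compound 1 `COc1cccc(N2C(=O)COc3ccc(-c4cnc(Cl)c(NS(=O)(=O)c5ccc(F)cc5)c4)cc32)c1` was examined in a functional assay on HeLa cells (Homo sapiens) for antiproliferative activity, read by MTT assay, with a stated time of 72 h; a higher number here means a weaker inhibitor, a lower number a stronger inhibitor. In that test compound 1 gives only a limit, > 40000 nM. Compound 2 `CC(C)N1C(=O)COc2ccc(-c3cnc(Cl)c(NS(=O)(=O)c4ccc(F)cc4)c3)cc21` gives 5380 nM in this assay. The change between them, (isopropyl in place of 3-methoxyphenyl on an amide-type nitrogen in a ring), brought an at least 7.4-fold lower number from compound 1 to compound 2 (0.87 log units; beyond the scatter); the step is stated as a bound because of the limit of > 40000 nM in this assay, at which 2 of the 3 values shown sit. Compound 3 `COc1cccc(N2C(=O)COc3ccc(-c4cccc(NS(=O)(=O)c5ccc(F)cc5)c4)cc32)c1` carries a different core, and the difference between the two cores is not broken down here. In this assay compound 3 gives only a limit, > 40000 nM. Compound 4 `CC(C)N1C(=O)COc2ccc(-c3cccc(NS(=O)(=O)c4ccc(F)cc4)c3)cc21` differs from compound 3 by the same change, (isopropyl in place of 3-methoxyphenyl on an amide-type nitrogen in a ring). If the change acts on this core as on the other, the expected step is an at least 2.6-fold lower number from compound 3 to compound 4 (0.42 log units; beyond the scatter), resting on an at least 7.4-fold lower number from compound 1 to compound 2 (0.87 log units; beyond the scatter). Compound 4 is therefore estimated at 15000 nM in this assay, between 5000 nM and 40000 nM.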

Compound 4, half-maximal inhibitory concentration: 22700 nM
For compound 4 the middle estimate is 1.5-fold (0.18 log units) below the measured one, within the range that was stated.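

Carried to the core of compound 3, the change of 3-methoxyphenyl to isopropyl gives in this assay an at least 1.7-fold lower number from compound 3 to compound 4 (0.24 log units; that floor lies within the scatter). This shows that the step on this core is compatible with the one on the core of compound 1, with both bounds pointing to a lower number, but the floor on this core does not by itself establish a real gain. It does not show that the change is worth the same on the two cores: the same change on two cores in this assay, an at least 7.4-fold lower number (0.87 log units; beyond the scatter) from compound 1 to compound 2 and an at least 1.7-fold lower number (0.24 log units; that floor lies within the scatter) from compound 3 to compound 4; the limit leaves it open whether they differ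

The compounds shown leave open how a methyl group, a longer chain or a chain ending in an amine would behave on the same amide-type nitrogen. They also leave open whether any such group would bring either core much below the values seen with isopropyl in this assay.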